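Replacing methoxycarbonyl in compound 3 with (1,3-dicarboxypropyl)amino

The compounds below may be only part of what the source reports. "The series", "measured", "known", "first", "only" and "open" are said of these compounds alone.

Measured in a functional assay on CCRF-CEM cells (Homo sapiens) for cytotoxicity, in the absence of a further agent (on this read-out lower numbers stand for stronger inhibition and higher numbers for weaker inhibition), so far:
- Compound 1 (`COC(=O)c1ccc(CN(CCCc2c(N)nc(N)nc2O)c2cc(F)cc(F)c2[N+](=O)[O-])cc1`) gives > 100000 nM (a limit of the assay)
- Compound 2 (`Nc1nc(N)c(CCCN(Cc2ccc(NC(CCC(=O)O)C(=O)O)cc2)c2cc(F)c([N+](=O)[O-])cc2[N+](=O)[O-])c(O)n1`) gives 51000 nM (a measured number)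
- Compound 3 (`COC(=O)c1ccc(CN(CCCc2c(N)nc(N)nc2O)c2cc(F)c(F)cc2[N+](=O)[O-])cc1`) gives 66000 nM (a measured number)

Compound 3 and compound 2 lie within the scatter of each other. Compound 1 reports only a limit. Compound 4 (`Nc1nc(N)c(CCCN(Cc2ccc(NC(CCC(=O)O)C(=O)O)cc2)c2cc(F)c(F)cc2[N+](=O)[O-])c(O)n1`) carries (1,3-dicarboxypropyl)amino in place of methoxycarbonyl on an aromatic carbon, para to a large group ((1,3-dicarboxypropyl)amino in place of methoxycarbonyl on an aromatic carbon). For the measured compounds named here, the one measured step (an at least 1.5-fold lower number from compound 1 to compound 3 (0.18 log units; that floor lies within the scatter)) moves only the fluorines and leaves this group untouched. Compound 2 carries the entering group on a differently substituted nitrophenyl and gives 51000 nM within the scatter of compound 3. The expected 1.3-fold lower number from compound 3 to compound 4 (0.12 log units; within the scatter) therefore stays within the scatter. Compound 4 is estimated at 50000 nM (expected range 15000 nM to 100000 nM).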

Compound 4, half-maximal inhibitory concentration: > 100000 nM
Compound 4 ended at the assay's limit; the forecaster's own chance of this, stated with the estimate: 30%; middle value at least 2.0-fold (0.30 log units) from the limit.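

On this aromatic carbon, (1,3-dicarboxypropyl)amino brings no measurable gain over methoxycarbonyl in this assay: compound 4 gives > 100000 nM, which is a limit of the assay. The change shows an at least 1.5-fold higher number from compound 3 to compound 4 (0.18 log units; that floor lies within the scatter), while fluoro in place of nitro shows an at least 1.9-fold higher number from compound 2 to compound 4 (0.29 log units; that floor lies within the scatter). Neither step can be sized, because both end at the assay's ceiling: the limit of > 100000 nM in this assay, at which 2 of the 4 values shown sit.

The compounds shown leave open whether a single carboxylic acid or an amide on this aromatic carbon would give a number clearly lower than that of compound 3.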